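A few compounds are considered here, and "the series" means these few. Any claim that something is new, unique, unknown or untested is made for them only; others in the source may bear on it.

The study sets three measured compounds and one unmeasured one against a toxicity assay on MDCK cells (Canis lupus familiaris) for cytotoxicity, read by crystal violet staining, with a stated time of 48 h; a higher number here means that more compound is tolerated, a lower number that less compound is tolerated. Compound 1, `Cc1ccc2cc(CN(Cc3ccc(C(C)(C)C)cc3)C3CCCC3)c(=O)[nH]c2c1`, reaches only a limit in this assay: its value of > 10000 nM is a limit of the assay rather than a number. Compound 2, `CCc1ccc2cc(CN(Cc3ccc(C(C)(C)C)cc3)C3CCCC3)c(=O)[nH]c2c1`, likewise stops at a limit in this assay, giving > 9000 nM. The change from compound 1 to compound 2 is methyl in place of hydrogen on a saturated chain carbon bound to an aromatic carbon, and the step that the two limits leave unreadable from compound 1 to compound 2 cannot be sized, because the limit of > 10000 nM in this assay, at which 2 of the 3 values shown sit, holds compound 1 and the limit of > 9000 nM in this assay, at which 1 of the 3 values shown sits, holds compound 2.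

Compound 3, `COc1ccc(CN(Cc2ccc(C(C)(C)C)cc2)Cc2cc3cc(C)ccc3[nH]c2=O)cc1`, carries a different core; how the two cores differ is not broken down here. In this assay compound 3 also gives > 10000 nM, again a limit.

Compound 4, `CCOc1ccc(CN(Cc2ccc(C(C)(C)C)cc2)Cc2cc3cc(C)ccc3[nH]c2=O)cc1`, is the unmeasured partner of compound 3 and differs from it by methyl in place of hydrogen on a saturated chain carbon bound to an oxygen on an aromatic ring. This is the same kind of change as that from compound 1 to compound 2, not the same: there the methyl entered on a saturated chain carbon bound to an aromatic carbon, here on a saturated chain carbon bound to an oxygen on an aromatic ring. The earlier step could not be read, and every measured value sits at a limit. The expectation for compound 4 therefore rests on compound 3, whose value > 10000 nM is a limit. Compound 4 is expected to stay at the limit as well, an estimated step of a number no higher from compound 3 to compound 4 (the limit leaves the size open). The estimate for compound 4 in this assay is 10000 nM, with a range from 5000 nM to 20000 nM.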

Compound 4, half-maximal cytotoxic concentration: > 10000 nM
Compound 4 ended at the assay's limit; the forecaster's own chance of this, stated with the estimate: 85%; the middle value sits exactly at the limit.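

Compound 4 ends at a limit of the assay, as compound 3 does, and no step between compound 3 and compound 4 can be read, because neither gives a number: the limit of > 10000 nM in this assay, at which 3 of the 4 values shown sit.

The compounds shown leave open what concentration of any of them is actually tolerated in this assay, and whether methyl in place of hydrogen changes that tolerance at either place.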